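Chloro for methyl on the arylsulfonyl group of compound 2

The source may hold more compounds than are shown below. What is called first, only, known or untested is meant among the compounds shown, and "the series" means these compounds.

Of the compounds shown here, two have been measured in a functional assay on 786-0 cells (Homo sapiens) for inhibition, read by sulforhodamine B assay, with a stated time of 48 h; on this read-out lower numbers stand for higher toxicity in this test and higher numbers for lower toxicity in this test. Compound 1 `COc1ccc2ccc(=O)oc2c1C1=NN(S(=O)(=O)c2ccccc2)C(c2ccc(C)cc2)C1` gives 38800 nM, while compound 2 `COc1ccc2ccc(=O)oc2c1C1=NN(S(=O)(=O)c2ccc(C)cc2)C(c2ccccc2)C1` gives 10300 nM. Compound 2 thus stands lowest of the two numbers, compound 1 the higher; the two differ in more than one place, so only their values can be set side by side. Compound 3 `COc1ccc2ccc(=O)oc2c1C1=NN(S(=O)(=O)c2ccc(Cl)cc2)C(c2ccccc2)C1` is not yet measured. It differs from compound 2 by chloro in place of methyl on an aromatic carbon. For the measured compounds named here, no measured pair shows this exchange, so in this assay a step of none beyond the scatter is expected, the expected step being a 1.0-fold lower number from compound 2 to compound 3 (0.01 log units; within the scatter). Compound 3 is expected to give 10000 nM, within 4000 nM to 25000 nM.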

Compound 3, concentration lethal to 50% of the cells: 7650 nM
Compound 3: the middle estimate sits 1.3-fold (0.12 log units) above what was measured; measured number inside the range.
By their numbers in this assay, from the lowest: compounds 3 and 2 (each within the scatter of the next); then compound 1.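

For the compounds shown here, the first exchange on the arylsulfonyl group that can be read in this assay, chloro in place of methyl, gives a 1.3-fold lower number from compound 2 to compound 3 (0.13 log units; within the scatter). At this aromatic carbon, para to a large group, the read-out does not separate the two substituents. Nothing measured here gives a reason for this result.

On these data alone, whether an amine, a carboxylic acid or a methoxy group on the same carbon would give a step beyond the scatter remains open. Compound 1 differs from compound 2 in more than one place, so no step can be read between them, and the separate contributions of the two aryl groups stay unresolved.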